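The source may report more compounds than this note shows. Statements on the series, on what has been measured and on what is new or still open speak of the compounds shown alone.

Compound 1, built as `CCCCc1nnc(O)n2c(CCC)nc(C)c12`, is the starting point of this account. In a functional assay for inhibition, with Homo sapiens as the target (a lower number here means a stronger inhibitor, a higher number a weaker inhibitor), compound 1 gives only a limit, > 48000 nM, and not a number. The two other compounds that have been tested in this assay tell the same story. Compound 2, `Cc1ncc2cnnc(O)n12`, returns in this assay the limit > 48000 nM. Compound 3, `CCc1nnc(S)n2c(C(C)CC)nc(C)c12`, likewise returns in this assay the limit > 48000 nM. So compound 1 stands nowhere in particular among the numbers shown: every value here is the limit of > 48000 nM in this assay, at which 3 of the 3 values shown sit, and no compound can be placed above or below another.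

The compound that has not yet been measured is compound 4, `CCCc1nc(C)c2c(C)nnc(O)n12`. It differs from compound 1 in one place, (hydrogen in place of propyl on a saturated chain carbon bound to an aromatic carbon), which, read one bond further out, is butyl becoming methyl. Among the compounds with values here, no step between measured compounds is available to say what such a shortening does in this assay, and with every measured value sitting at the limit, there is no number from which a step could be counted.

The expectation for compound 4 is therefore that the step from compound 1 to compound 4 in this assay, a step that the limit leaves unreadable from compound 1 to compound 4, shows nothing beyond the scatter. Compound 4 is estimated in this assay at 60000 nM, within a range from 20000 nM to 200000 nM, most likely reported again as a limit.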

Compound 4, half-maximal inhibitory concentration: 14000 nM
Compound 4: middle estimate off by 4.3-fold (0.63 log units), on the high side; the whole stated range lies above it.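

Within the data shown here, replacing butyl with methyl, with hydrogen in place of propyl on a saturated chain carbon bound to an aromatic carbon, gives the first step that can be read in this assay, an at least 3.4-fold lower number from compound 1 to compound 4 (0.53 log units; beyond the scatter), and so shows that the length of the chain at this place can move the result beyond the scatter. Compound 4, at 14000 nM, is the only compound shown that gives a number, which provides a first value against which later changes in this assay can be counted. The true size of the step remains unknown, however, and it can be stated only as a bound because compound 1 has a limit and not a number: the limit of > 48000 nM in this assay, at which 3 of the 4 values shown sit.

No other step among the compounds shown can be read, so the effect of the groups elsewhere on the core stays unknown. The compounds shown also leave open whether the number would keep falling with a still smaller group at this place, such as a bare hydrogen, or how a cyclopropyl, a trifluoromethyl or an amine there would compare with methyl.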